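This account rests on a few compounds, and the source may have more. Where it says the series, first, only, none or still open, it means among the compounds named here.

In a functional assay on OCI-Ly3 cells (Homo sapiens) for antiproliferative activity (on this read-out higher numbers stand for an effect only at larger amounts of compound and lower numbers for an effect already at smaller amounts), compound 2 (`COC(C)(C)c1c(NC(=O)Nc2cnc(-n3nccn3)c(Cl)c2)cnc2ccc(F)cc12`) gives 410 nM and compound 1 (`CC(O)c1c(NC(=O)Nc2cnc(-n3nccn3)c(Cl)c2)cnc2ccccc12`) gives 730 nM on the same read-out. These two values lie within the usual scatter of each other, so compound 2 stands level with compound 1 and the numbers do not rank them.

Compound 3 (`CC(O)c1c(NC(=O)Nc2cnc(-n3nccn3)c(Cl)c2)cnc2ccc(F)cc12`) has not yet been measured. It differs from compound 2 by one change on an aromatic carbon opposite the ring nitrogen, with 1-hydroxyethyl in place of 1-methoxy-1-methylethyl (1-hydroxyethyl in place of 1-methoxy-1-methylethyl on an aromatic carbon). Among the compounds with values here, no measured pair shows this change on its own, so the data give no direct size for it. The nearest guide is compound 1, which also carries 1-hydroxyethyl and gives 730 nM in this assay while staying within the scatter of compound 2. The change is therefore expected to bring no step beyond the scatter, with at most a slight lean towards a higher number. The estimated 1.3-fold higher number from compound 2 to compound 3 (0.13 log units; within the scatter) is expected to remain small on this scale. Compound 3 is estimated at 550 nM as a middle value, with an expected range from 200 nM up to 1500 nM at its ends.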

Compound 3, half-maximal effective concentration: 560 nM
The estimate for compound 3 lay 1.0-fold (0.01 log units) below the measured number, and the stated range covers the measured number.
By their numbers in this assay, from the lowest: compounds 2, 3 and 1 (each within the scatter of the next).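

In this assay, the step for 1-hydroxyethyl in place of 1-methoxy-1-methylethyl on the aromatic carbon opposite the ring nitrogen is a 1.4-fold higher number from compound 2 to compound 3 (0.14 log units; within the scatter) and is now measured directly, showing that this swap to a smaller group with a hydrogen-bond donor brings no step beyond the scatter. Fluoro in place of hydrogen on an aromatic carbon can now also be read on its own, as a 1.3-fold lower number from compound 1 to compound 3 (0.12 log units; within the scatter) in this assay, and this change likewise does not separate the two compounds on this read-out. The compounds shown offer no measurement that would explain either result.

The swap at this position changes the oxygen substituent and the carbon branching together, so a group such as 1-hydroxy-1-methylethyl would be needed to read those two parts apart. On these data alone, what an amine, a carboxylic acid or a longer chain would do at this position also remains open, as does whether a chloro group in place of the fluoro would give a step beyond the scatter.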